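The source may hold more compounds than are shown below. What is called first, only, known or untested is meant among the compounds shown, and "the series" means these compounds.

Measured compounds:
- Compound 1 `Cc1cc(C)cc(C(=O)Nc2nc3ccc(NC(=O)CSc4ccc(Cl)cc4)cc3s2)c1` gives > 100000 nM in a functional assay on U2OS cells (Homo sapiens) for antiproliferative activity, read by MTT assay, with a stated time of 72 h; a lower number here means a stronger inhibitor, a higher number a weaker inhibitor.
- Compound 2 `O=C(Cc1nnc(NC(=O)c2ccc(Cl)cc2)s1)N/N=C/c1ccc(O)cc1` gives > 100000 nM in this assay.
- Compound 3 `Cc1cc(C)cc(C(=O)Nc2nc3ccc(NC(=O)CSc4cccc(O)c4)cc3s2)c1` gives 2820 nM in this assay.

The value of compound 1 is a limit of the assay, not a number. The value of compound 2 is likewise a limit. Compound 1 therefore stands at the weak end of what was measured, with only compound 3 showing a number. Among the compounds with values here, the one step between measured compounds, an at least 35-fold lower number from compound 1 to compound 3 (1.54 log units; beyond the scatter), alters the group on the sulfur, and it is large. Compound 4 `Cc1ccc(C(=O)Nc2nc3ccc(NC(=O)CSc4ccc(Cl)cc4)cc3s2)cc1` differs from compound 1 elsewhere: 4-methylphenyl in place of 3,5-dimethylphenyl on a carbonyl carbon. No measured step touches the carbonyl-attached ring, so nothing shown tells how this change acts. Because (the limit of > 100000 nM in this assay, at which 2 of the 3 values shown sit), and because the change is a small one of 4-methylphenyl in place of 3,5-dimethylphenyl on a carbonyl carbon, compound 4 is expected to stay near the limit, a step of a number no higher from compound 1 to compound 4 (the limit leaves the size open). Compound 4 is estimated at 100000 nM, between 30000 nM and 300000 nM.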

Compound 4, half-maximal inhibitory concentration: 3190 nM
Estimate against measurement, compound 4: 31-fold (1.50 log units) above, outside the stated range (below it).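

Replacing 3,5-dimethylphenyl with 4-methylphenyl on a carbonyl carbon gives an at least 31-fold lower number from compound 1 to compound 4 (1.49 log units; beyond the scatter) in this assay, so a small change in this ring, from 8 heavy atoms to 7, can matter greatly. Until now, only the group on the sulfur had been seen to move a compound away from the limit; this second position can do so too, and compound 4 keeps the 4-chlorophenyl on the sulfur, so that group alone does not hold a compound at the limit. The true size of the step stays unknown, since the value of compound 1 is only a limit: the limit of > 100000 nM in this assay, at which 2 of the 4 values shown sit.

The compounds shown leave open how an unsubstituted phenyl or a 4-aminophenyl would behave on this carbonyl carbon. They also leave open whether 4-methylphenyl there and 3-hydroxyphenyl on the sulfur would add up in one compound.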